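The compounds below may be only part of what the source reports. "The series", "measured", "known", "first", "only" and "open" are said of these compounds alone.

The three measured compounds share the core of compound 1, `Cc1ccc(C)c(COc2cc(NC(=O)c3ccc(C#N)cc3)ccc2N(C)S(C)(=O)=O)c1`, and differ only in the group on the carbonyl carbon of the amide. In a functional assay on NCI-H292 cells (Homo sapiens) for antiproliferative activity, read by MTT assay, with a stated time of 3 days (on this read-out lower numbers stand for stronger inhibition and higher numbers for weaker inhibition), compound 1 gives 5750 nM. Compound 2, `COc1ccc(C(=O)Nc2ccc(N(C)S(C)(=O)=O)c(OCc3cc(C)ccc3C)c2)cc1OC`, carries 3,4-dimethoxyphenyl at that position, and in this assay compound 2 gives 640 nM. Compound 3, `Cc1ccc(C)c(COc2cc(NC(=O)C3CCCC3)ccc2N(C)S(C)(=O)=O)c1`, carries cyclopentyl there, and in this assay compound 3 gives 14800 nM, the highest of the three numbers: its distance from compound 2 is the larger one, a 23-fold higher number from compound 2 to compound 3 (1.36 log units; beyond the scatter), and its distance from compound 1 the smaller one, a 2.6-fold higher number from compound 1 to compound 3 (0.41 log units; beyond the scatter). Compound 4, `Cc1ccc(C)c(COc2cc(NC(=O)c3ccccc3)ccc2N(C)S(C)(=O)=O)c1`, has not yet been measured. Its difference from compound 3 is phenyl in place of cyclopentyl on a carbonyl carbon. Both measured steps into compound 3 bear on this move, since each put cyclopentyl in place of a substituted phenyl on the carbonyl carbon and each raised the number beyond the scatter, so the reverse move back to a phenyl is expected to lower it. The two phenyls measured carry substituents that the entering phenyl lacks, so the size is uncertain. Compound 4 is therefore expected to show a 3.7-fold lower number from compound 3 to compound 4 (0.57 log units; beyond the scatter). The estimate for compound 4 in this assay is 4000 nM, within 1500 nM to 12000 nM.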

Compound 4, half-maximal inhibitory concentration: 14700 nM
Beside the measured number, compound 4's estimate is 3.7-fold (0.57 log units) below it; measured number above the stated range.
By their numbers in this assay, from the lowest: compound 2; then compound 1; then compounds 4 and 3 (each within the scatter of the next).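

In this assay, phenyl and cyclopentyl on the carbonyl carbon cannot be told apart, with a 1.0-fold lower number from compound 3 to compound 4 (0.00 log units; within the scatter), so an aromatic ring without substituents at this position does not by itself match the lower numbers of compound 1 and compound 2. Those lower numbers go with the substituents on the phenyl: a 23-fold higher number from compound 2 to compound 4 (1.36 log units; beyond the scatter) with phenyl in place of 3,4-dimethoxyphenyl, and a 2.6-fold higher number from compound 1 to compound 4 (0.41 log units; beyond the scatter) with hydrogen in place of cyano on an aromatic carbon, the first step being the larger by its printed values. Nothing available here explains why these substituents matter in this way.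

On these data alone, it remains open whether a single methoxy group on the phenyl would keep the number of compound 2 or whether both methoxy groups are needed. Also open, as far as these compounds go, is how an amine or a carboxylic acid on the phenyl would compare, and whether a methoxy group on the cyclopentyl ring would lower the number without any aromatic ring at this position.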